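Compound 4: trifluoromethoxy in place of ethyl

The source may hold more compounds than are shown below. What is called first, only, known or untested is meant among the compounds shown, and "the series" means these compounds.

Measured in a functional assay for agonist activity at G protein-coupled receptor 88 (Homo sapiens), read by HTRF and cAMP accumulation; on this read-out lower numbers stand for an effect already at smaller amounts and higher numbers for an effect only at larger amounts of compound:
compound 1 `Cc1ccc(-c2ccc(N(C[C@@H](N)CC(C)C)C(=O)[C@@H]3C[C@H]3c3ccccc3)cc2)cc1` – 360 nM
compound 2 `Cc1cccc(-c2ccc(N(C[C@@H](N)CC(C)C)C(=O)[C@@H]3C[C@H]3c3ccccc3)cc2)c1` – 1200 nM
compound 3 `CCc1ccc(-c2ccc(N(C[C@@H](N)[C@@H](C)CC)C(=O)[C@@H]3C[C@H]3c3ccccc3)cc2)cc1` – 44 nM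

Compound 3 stands lowest of the three numbers; compound 1 and compound 2 both lie beyond the scatter above it. Compound 4 `CC[C@H](C)[C@H](N)CN(C(=O)[C@@H]1C[C@H]1c1ccccc1)c1ccc(-c2ccc(OC(F)(F)F)cc2)cc1` differs from compound 3 by trifluoromethoxy in place of ethyl on an aromatic carbon. Among the measured compounds shown here, the only single-change step measured, a 3.3-fold higher number from compound 1 to compound 2 (0.52 log units; beyond the scatter), moves a methyl on the same ring and does not exchange one group for another; no measured pair bears directly on ethyl against trifluoromethoxy, and compound 3 differs from compound 1 in two places, so that gap cannot be assigned. With the substituent kept on the same aromatic carbon, a step of modest size, slightly upward, is expected: a 1.8-fold higher number from compound 3 to compound 4 (0.26 log units; within the scatter). For compound 4 the number expected in this assay is 80 nM, range 25 nM to 300 nM.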

Compound 4, half-maximal effective concentration: 170 nM
For compound 4 the middle estimate is 2.1-fold (0.33 log units) below the measured one; the range from low to high includes it.
By their numbers in this assay, from the lowest: compound 3; then compound 4; then compound 1; then compound 2.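

In this assay, among the compounds shown here, 4-(trifluoromethoxy)phenyl in place of 4-ethylphenyl gives a 3.9-fold higher number from compound 3 to compound 4 (0.59 log units; beyond the scatter), the only measured exchange of one group for another on this ring. The number therefore responds to which group occupies this aromatic carbon, whereas the earlier methyl step showed only a response to the group's location. Nothing measured accounts for this step. Still open, going by these compounds, is how a methoxy group, chlorine or a nitrile would read on this carbon. Ethyl against methyl also stays unresolved, as compound 1 and compound 3 differ in two places.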